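A Methoxycarbonyl Swap in a Cytotoxic Series

This account rests on a few compounds, and the source may have more. Where it says the series, first, only, none or still open, it means among the compounds named here.

In a functional assay on MDA-MB-231 cells (Homo sapiens) for cytotoxicity, read by MTT assay, with a stated time of 24 h (on this read-out higher numbers stand for weaker inhibition and lower numbers for stronger inhibition), compound 1 `Fc1ccc(-c2nc3cccnc3n2C2CCCC2)cc1` stands at 500 nM and compound 2 `FC(F)(F)Oc1cccc(-c2nc3cccnc3n2C2CCCC2)c1` at 262 nM so that the two lie within the usual scatter of each other. Compound 3 `COc1ccc(-c2nc3cccnc3n2C2CCCCC2)cc1` reads 112 nM and thus lies beyond the scatter on the stronger side of compound 1. The change methoxycarbonyl in place of fluoro on an aromatic carbon puts methoxycarbonyl in place of fluoro on an aromatic carbon, para to a large group, and yields compound 4 `COC(=O)c1ccc(-c2nc3cccnc3n2C2CCCC2)cc1` which awaits measurement. Going by the values given here, no measured pair differs in only one place, so the data give no size for such a step in this assay and none beyond the scatter is expected. The estimated step of a 1.7-fold lower number from compound 1 to compound 4 (0.22 log units; within the scatter) stays inside the scatter. For compound 4 the estimated value is 300 nM with an expected range from 100 nM to 900 nM on this read-out.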

Compound 4, half-maximal inhibitory concentration: 350 nM
For compound 4 the middle estimate is 1.2-fold (0.07 log units) below the measured one, and the stated range covers the measured number.
By their numbers in this assay, from the lowest: compound 3; then compounds 2, 4 and 1 (each within the scatter of the next).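

Going by these compounds alone, the step of a 1.4-fold lower number from compound 1 to compound 4 (0.15 log units; within the scatter) in this assay is the first comparison that differs in one place only. It shows that methoxycarbonyl can take the place of fluoro on this aromatic carbon, para to a large group, with the two compounds remaining within the scatter of each other, even though the entering group is larger and carries hydrogen-bond acceptors. No available evidence bears on this result.

On these data alone, whether a carboxylic acid or an amine at this place would give a step beyond the scatter remains open. So does whether the same swap would give a similar step in any other compound.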